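Chloro to Fluoro on the Aromatic Ring of Compound 1

The compounds below may be only part of what the source reports. "The series", "measured", "known", "first", "only" and "open" are said of these compounds alone.

Measured compounds:
Compound 1 `Cc1nc(N(C)c2ccc([Se]C#N)c(Cl)c2)c2ccccc2n1`, 7 nM
Compound 2 `C[Se]c1ccc(N(C)c2nc(C3CC3)nc3ccccc23)cc1`, 13 nM

In a functional assay on A549 cells (Homo sapiens) for inhibition, read by MTT assay, with a stated time of 48 h (on this read-out lower numbers stand for stronger inhibition and higher numbers for weaker inhibition), compound 1 gives 7 nM, the lower of the two numbers, though compound 2 with 13 nM lies within the scatter of it. Compound 3 `Cc1nc(N(C)c2ccc([Se]C#N)c(F)c2)c2ccccc2n1` is not yet measured. It differs from compound 1 by fluoro in place of chloro on an aromatic carbon. Within the data shown here, with no measured pair showing such a swap, the step of a 1.4-fold higher number from compound 1 to compound 3 (0.15 log units; within the scatter) is expected to be small, at most a slight loss not clearly beyond the scatter. Compound 3 is thus estimated at 10 nM, with a range from 4 nM to 25 nM.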

Compound 3, half-maximal inhibitory concentration: 4 nM
Beside the measured number, compound 3's estimate is 2.5-fold (0.40 log units) above it, and the stated range covers the measured number.
By their numbers in this assay, from the lowest: compounds 3, 1 and 2 (each within the scatter of the next, the first and the last beyond it).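

In this assay the swap of chloro for fluoro on this aromatic carbon, ortho to a group of 3 heavy atoms and meta to a large group, gives a 1.8-fold lower number from compound 1 to compound 3 (0.24 log units; within the scatter) and so stays within the usual scatter. Among these compounds, this is the first measured pair differing in one place, and it shows that either halogen is tolerated here in the core of compound 1. Nothing at hand gives a reason for this step. Going by these compounds, what remains open is how this carbon responds to a non-halogen group, such as a methyl, a methoxy or an amine.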